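Notes on replacing bromo with amino in compound 2

The source may report more compounds than this note shows. Statements on the series, on what has been measured and on what is new or still open speak of the compounds shown alone.

Measured in a functional assay on MCF7 cells (Homo sapiens) for antiproliferative activity, read by MTT assay, with a stated time of 48 h; on this read-out lower numbers stand for stronger inhibition and higher numbers for weaker inhibition
- compound 1 `COc1ccc(C(=O)c2ccc(OC)c3c2OC(C)(C)C=C3)c(NC(=O)CBr)c1` gives 2360 nM
- compound 2 `COc1ccc(C(=O)c2ccc(OC)c3c2C=CC(C)(C)O3)c(NC(=O)CBr)c1` gives 3290 nM
- compound 3 `COc1ccc(C(=O)c2ccc(OC)c3c2OC(C)(C)C=C3)c(NC(=O)CO)c1` gives 320 nM

Compound 2 has the highest number of the three, but it lies within the scatter of compound 1 and beyond the scatter above compound 3. Compound 4 `COc1ccc(C(=O)c2ccc(OC)c3c2C=CC(C)(C)O3)c(NC(=O)CN)c1` carries amino in place of bromo on a saturated chain carbon bound to a carbonyl carbon. Among the measured compounds shown here, no amino compound has been measured. The nearest evidence is the modest hydroxy-for-bromo step a 7.4-fold lower number from compound 1 to compound 3 (0.87 log units; beyond the scatter), taken on the core of compound 1. A lower number of similar or somewhat smaller size is therefore expected in this assay. The estimated change is a 4.1-fold lower number from compound 2 to compound 4 (0.61 log units; beyond the scatter). For compound 4 the expected value is 800 nM, with an estimated range of 200 nM to 3200 nM.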

Compound 4, half-maximal inhibitory concentration: 1250 nM
For compound 4 the middle estimate is 1.6-fold (0.19 log units) below the measured one, and the stated range covers the measured number.
By their numbers in this assay, from the lowest: compound 3; then compounds 4, 1 and 2 (each within the scatter of the next, the first and the last beyond it).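

In this assay, amino in place of bromo gives a 2.6-fold lower number from compound 2 to compound 4 (0.42 log units; beyond the scatter). A replacement of bromo on a saturated chain carbon bound to a carbonyl carbon therefore lowers the number on the core of compound 2 too, not only on the core of compound 1, where the hydroxy change gives a 7.4-fold lower number from compound 1 to compound 3 (0.87 log units; beyond the scatter). No measured evidence bears on what lies behind the new step.

Open questions are how hydroxy behaves on the core of compound 2 and how a carboxylic acid or a dimethylamino group would fare at this place.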